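This account rests on a few compounds, and the source may have more. Where it says the series, first, only, none or still open, it means among the compounds named here.

Measured compounds:
compound 1, `COc1ccc2nc(N(Cc3cc(-c4ccc(SC(F)(F)F)cc4)no3)c3nc4ccc(F)cc4s3)sc2c1`: 26500 nM
compound 2, `COc1ccc2nc(N(Cc3cc(-c4ccc(Br)cc4)no3)c3nc4ccc(F)cc4s3)sc2c1`: 32700 nM

In a functional assay on A549 cells (Homo sapiens) for antiproliferative activity, read by MTT assay (on this read-out lower numbers stand for stronger inhibition and higher numbers for weaker inhibition), compound 2 gives 32700 nM, and compound 1 gives 26500 nM. Among the compounds with values here, the only measured step, a 1.2-fold higher number from compound 1 to compound 2 (0.09 log units; within the scatter), shows that exchanging one halogen-type substituent on the pendant phenyl ring for another left the read-out essentially unchanged. Compound 2 therefore stands alongside compound 1 rather than apart from it, and neither can be called the more or less potent of the two.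

Compound 3, `COc1ccc2nc(N(Cc3cc(-c4ccccc4F)no3)c3nc4ccc(F)cc4s3)sc2c1`, differs from compound 2 by 2-fluorophenyl in place of 4-bromophenyl on an aromatic carbon. This change, as the two group names show, alters both the halogen and the numbering of the substituent on that ring, so the step from compound 1 to compound 2 is only a partial guide: it bears on a halogen swap on this phenyl ring and was within the scatter. Within the data shown here, no measured pair addresses a 2-fluorophenyl group here. The expectation for compound 3 is accordingly a step of about a 1.1-fold higher number from compound 2 to compound 3 (0.03 log units; within the scatter), that is, no change beyond the scatter. Compound 3 is estimated at 35000 nM, with a range from 15000 nM to 85000 nM.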

Compound 3, half-maximal inhibitory concentration: 51800 nM
Estimate against measurement, compound 3: 1.5-fold (0.17 log units) below, within the range that was stated.
By their numbers in this assay, from the lowest: compounds 1, 2 and 3 (each within the scatter of the next).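

In this assay replacing 4-bromophenyl with 2-fluorophenyl, on an aromatic carbon of the five-membered aromatic ring with 1 nitrogen and 1 oxygen, gives a 1.6-fold higher number from compound 2 to compound 3 (0.20 log units; within the scatter) and replacing 4-((trifluoromethyl)sulfanyl)phenyl with the same 2-fluorophenyl gives a 2.0-fold higher number from compound 1 to compound 3 (0.29 log units; within the scatter) on this read-out. The earlier step compared only 4-bromophenyl with 4-((trifluoromethyl)sulfanyl)phenyl; with 2-fluorophenyl included, all three compounds remain within the scatter of one another, so this read-out does not separate a change of both the halogen and its numbering on the phenyl ring from the other two groups. No independent measurement is available to explain these values.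

From the compounds shown here alone, the step to 2-fluorophenyl alters the halogen and its numbering together, so the share of each remains open, and a comparison of 4-fluorophenyl with 4-bromophenyl would address the halogen alone. All three compounds also carry a halogen-bearing or sulfur-bearing phenyl group at this place, which leaves open whether an amine or a carboxylic acid on that phenyl ring would give a step beyond the scatter.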